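The compounds below may be only part of what the source reports. "The series", "measured", "known", "first", "only" and "open" are said of these compounds alone.

Of the compounds shown here, three have so far been measured in an assay on microsomes from intestine for inhibition of acyl-CoA:cholesterol acyltransferase (Oryctolagus cuniculus); a lower number here means a stronger inhibitor, a higher number a weaker inhibitor. Compound 1, `CC(C)c1cccc(C(C)C)c1NC(=O)Nc1nn[nH]n1`, carries only a small heteroaromatic ring on one side of the shared core, and in this assay compound 1 gives > 10000 nM, which is a limit of the assay rather than a number. Compound 2, `CCCCCCCCCCCCCc1nnc(NC(=O)Nc2c(C(C)C)cccc2C(C)C)s1`, carries a long saturated chain on its ring, and in this assay compound 2 gives 36 nM. Compound 3, `CCCCCCCCCCCCCCc1cc(NC(=O)Nc2c(C(C)C)cccc2C(C)C)on1`, carries a similar long chain on a different ring, and in this assay compound 3 gives 28 nM. Compound 3 has the lowest of the two numbers shown, but its gap to compound 2 lies within the usual scatter, so the two cannot be ranked against each other. The one result that stands apart is the limit of > 10000 nM in this assay, at which 1 of the 3 values shown sits, which belongs to compound 1.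

Compound 4, `CCCCCCCCCCCCc1cc(NC(=O)Nc2c(C(C)C)cccc2C(C)C)on1`, has not yet been measured. It differs from compound 3 by hydrogen in place of ethyl on a saturated chain carbon, ten or more bonds along the chain from an aromatic carbon. Among the measured compounds shown here, no pair of measured compounds shows this exact change, so nothing measured tells how far the number moves. Shortening a long chain by two carbons is expected to matter little, and the step is estimated as a 1.4-fold higher number from compound 3 to compound 4 (0.15 log units; within the scatter), a small move toward a weaker inhibitor. In this assay compound 4 is expected to give about 40 nM, most likely between 15 nM and 120 nM.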

Compound 4, half-maximal inhibitory concentration: 19 nM
For compound 4 the middle estimate is 2.1-fold (0.32 log units) above the measured one; measured number inside the range.
By their numbers in this assay, from the lowest: compounds 4, 3 and 2 (each within the scatter of the next). At a limit, above all of these: compound 1.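

Among the compounds shown here, this is the first pair in the set that differs in only one place, so it is the first direct reading of a single change. In this assay, putting hydrogen in place of ethyl on a saturated chain carbon, ten or more bonds along the chain from an aromatic carbon, gives a 1.5-fold lower number from compound 3 to compound 4 (0.17 log units; within the scatter), so the two compounds cannot be told apart and this part of the chain can be trimmed without a readable change in the number. Nothing shown accounts for this result, and the one limit in the set, which belongs to a compound that differs from these two in more than one place, does not bear on this change.

For the compounds shown here, the single pair covers only one small trim of the chain, so it leaves open how much further the chain can be cut, and whether a hexyl chain in place of the long chain of compound 4 would still sit near these numbers. It also leaves open what a carboxylic acid or an amine would do in place of the ethyl at this same place, since only hydrogen and saturated carbon have been read there so far.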